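This account rests on a few compounds, and the source may have more. Where it says the series, first, only, none or still open, it means among the compounds named here.

Compound 3 `O=S(=O)(c1ccccc1)c1cn(C2CCN(Cc3ccccc3)C2)c2ccccc12` has the highest number of the three measured in an assay on HeLa cells for displacement of a labelled ligand from 5-hydroxytryptamine receptor 6 (Homo sapiens), with a stated time of 2 h (a lower number here means a stronger inhibitor, a higher number a weaker inhibitor), where compound 3 gives 113 nM. Its nearest neighbour is compound 1 `O=S(=O)(c1ccccc1)c1cn(C2CCNCC2)c2ccccc12`, which in this assay gives 91 nM, a gap within the scatter; the furthest is compound 2 `CCN1CCCC(n2cc(S(=O)(=O)c3ccccc3)c3ccccc32)C1`, which in this assay gives 7.3 nM, a gap beyond the scatter. For the measured compounds named here, the one step measured so far is a 12-fold lower number from compound 1 to compound 2 (1.10 log units; beyond the scatter); it alters the ring attachment and the substituent on the ring nitrogen at the same time, so it does not separate the two effects.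

Compound 4 `O=S(=O)(c1ccccc1)c1cn(C2CCNC2)c2ccccc12` differs from compound 3 by hydrogen in place of benzyl on an amine nitrogen in a ring. Going by the values given here, no measured step removes a substituent from a ring amine nitrogen while leaving everything else unchanged. Compound 1, which carries an unsubstituted ring amine nitrogen, and compound 3, which carries a benzyl on its ring amine nitrogen, sit within the scatter of each other, which suggests that the nitrogen substituent by itself does not move the number far. The step from compound 3 to compound 4 is therefore expected to be small, a modest lowering if anything, a 1.6-fold lower number from compound 3 to compound 4 (0.21 log units; within the scatter). Compound 4 is estimated at 70 nM in this assay, with a range from 25 nM to 250 nM.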

Compound 4, inhibition constant: 5 nM
For compound 4 the middle estimate is 14-fold (1.15 log units) above the measured one, and the stated range ends above it.
By their numbers in this assay, from the lowest: compounds 4 and 2 (each within the scatter of the next); then compounds 1 and 3 (each within the scatter of the next).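

In this assay, removing the benzyl from the amine nitrogen of the five-membered ring gives a 23-fold lower number from compound 3 to compound 4 (1.35 log units; beyond the scatter), so the substituent on this nitrogen can carry a large effect, which the close values of compound 1 and compound 3 did not reveal, as those two also differ in their rings. An unsubstituted ring amine nitrogen does not by itself give a low number: pyrrolidin-3-yl in place of piperidin-4-yl gives an 18-fold lower number from compound 1 to compound 4 (1.26 log units; beyond the scatter), so ring size and attachment matter here as well, while a 1.5-fold lower number from compound 2 to compound 4 (0.16 log units; within the scatter) places the pyrrolidin-3-yl and 1-ethylpiperidin-3-yl compounds at the same level. Nothing available here explains the size of these steps.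

Going by these compounds, whether the loss seen with benzyl extends to other groups on the pyrrolidine nitrogen remains open, since a methyl or ethyl there would show whether any substituent raises the number or only a group as large as benzyl does. Also open, on these data alone, is how the piperidin-3-yl ring with hydrogen on its nitrogen compares, which would separate the ring attachment from the ethyl group in compound 2.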